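A few compounds are considered here, and "the series" means these few. Any claim that something is new, unique, unknown or untested is made for them only; others in the source may bear on it.

Measured compounds:
- compound 1 `N#C[C@@H]1CCCN1C(=O)[C@@H]1C[C@H](C(=O)N2CCCCCCC2)CN1`: "not determined" (no result reported)
- compound 2 `C[C@@H]1N[C@H](C(=O)N2CCC[C@H]2C#N)C[C@@H]1C(=O)N1CCC1`: 88%

Among the measured compounds shown here, compound 1 `N#C[C@@H]1CCCN1C(=O)[C@@H]1C[C@H](C(=O)N2CCCCCCC2)CN1` has no single number in an assay on the whole organism (plasma, strain Sprague-Dawley) for inhibition of Dipeptidyl peptidase 4 (Rattus norvegicus), with a stated time of 10 h, at a dose of 1 mg/kg by the oral route (on this read-out higher numbers stand for more inhibition at the one dose given (going by the name of the read-out) and lower numbers for less inhibition), so its standing on that read-out is unknown; the only measured point is compound 2, which in this assay gives 88%. Compound 2 shares the pyrrolidine-carbonitrile amide with compound 1 but carries a different core and an azetidine amide, so its value cannot be carried over to compound 1 directly.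

The new compound 3 `N#C[C@@H]1CCCN1C(=O)[C@@H]1C[C@H](C(=O)N2CCCCC2)CN1` differs from compound 1 in one place: a group of 6 heavy atoms (5 carbon, 1 nitrogen; one six-membered non-aromatic ring with 1 hetero atom) in place of a group of 8 heavy atoms (7 carbon, 1 nitrogen; one eight-membered non-aromatic ring with 1 hetero atom), on a carbonyl carbon. For the measured compounds named here, since compound 1 has no result in this assay, no measured step from compound 1 to compound 3 can be computed, and the expected size of the step in this assay cannot be stated as a change; the expectation for compound 3 rests on compound 2 alone. Because compound 2 gives 88% with a small ring amide of the same kind, a cyclic amide such as the piperidin-1-yl group of compound 3 is expected to give strong inhibition as well. Compound 3 is estimated to reach 75% in this assay, with a range from 40% to 95%.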

Compound 3, a percentage reported as inhibition, in the whole organism at one dose (the size of the read-out at that dose, not a potency): 50%
Compound 3: middle estimate off by 25 percentage points, on the high side, within the range that was stated.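

Compound 1 has no result in this assay, so the change from its eight-membered ring to the piperidin-1-yl group of compound 3 cannot be read as a step. No measurement shown here accounts for the result of compound 3. The compounds shown leave open whether the size of this ring on the carbonyl carbon affects inhibition at all.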